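A few compounds are considered here, and "the series" means these few. Any claim that something is new, unique, unknown or untested is made for them only; others in the source may bear on it.

Compound 1 `COc1ccc(CNc2nc3cc(N)cc(N)c3nc2-c2ccccc2)cc1OC` in a functional assay on K562 cells (Homo sapiens) for inhibition, read by sulforhodamine B assay, with a stated time of 48 h (on this read-out lower numbers stand for higher toxicity in this test and higher numbers for lower toxicity in this test), gives only an assay limit, < 100000 nM. Compound 2 `Nc1cc(N)c2nc(-c3ccccc3)c(NCc3ccc(F)cc3)nc2c1` in this assay likewise gives only a limit, < 100000 nM. The step that the two limits leave unreadable from compound 1 to compound 2 cannot be sized, since both values sit at the limit of < 100000 nM in this assay, at which 2 of the 2 values shown sit. Compound 3 `Nc1cc(N)c2nc(-c3ccccc3)c(Oc3ccc(F)cc3)nc2c1` differs from compound 2 by 4-fluorophenoxy in place of (4-fluorobenzyl)amino on an aromatic carbon. Among the measured compounds shown here, no measured step bears on this change; the single recorded step is itself unreadable. The expected step that the limit leaves unreadable from compound 2 to compound 3 is therefore not fixed in direction beyond the scatter. Compound 3 is estimated at 30000 nM, with a range of 5000 nM to 100000 nM, and a further limit is likely.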

Compound 3, concentration lethal to 50% of the cells: < 100000 nM
Compound 3 was reported as a limit; the forecaster's own chance of this, stated with the estimate: 60%; the middle value is on the limit's open side.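

No step can be read from compound 2 to compound 3, since both are reported only as limits: the limit of < 100000 nM in this assay, at which 3 of the 3 values shown sit.

Still open, on these data alone, is how far compounds 1, 2 and 3 actually lie apart in this assay and whether 4-fluorophenoxy in place of (4-fluorobenzyl)amino shifts the read-out at all.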